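Replacing a furan arm with naphthalene on a silent core

The compounds below may be only part of what the source reports. "The series", "measured", "known", "first", "only" and "open" are said of these compounds alone.

The measured compounds, each with its result in an assay on HL-60 cells for agonist activity at N-formyl peptide receptor 3 (Homo sapiens), read by calcium flux; a lower number here means that less compound is needed, a higher number that more compound is needed for the effect:
compound 1, `Cc1cc(Cc2cccc(Cl)c2)c(=O)n(CC(=O)Nc2ccc(Br)cc2)n1`, gives > 50000 nM in this assay.
compound 2, `Cc1cc(Cc2cccc(Br)c2)c(=O)n(CC(=O)Nc2ccc(Br)cc2)n1`, gives > 50000 nM in this assay.
compound 3, `Cc1cc(Cc2ccoc2)c(=O)n(CC(=O)Nc2ccc(Br)cc2)n1`, gives > 50000 nM in this assay.

Each of these three values is a limit of the assay, not a number. For compound 3 this means only that its result lies at the limit of > 50000 nM in this assay, at which 3 of the 3 values shown sit, with no measured value to place it against the others. The steps among the measured compounds share this problem: a step that the two limits leave unreadable from compound 1 to compound 2, a step that the two limits leave unreadable from compound 1 to compound 3 and a step that the two limits leave unreadable from compound 2 to compound 3 are all of unreadable size because of the limit of > 50000 nM in this assay, at which 3 of the 3 values shown sit.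

Compound 4, `Cc1cc(Cc2cccc3ccccc23)c(=O)n(CC(=O)Nc2ccc(Br)cc2)n1`, differs from compound 3 in one place: naphthalen-1-yl in place of furan-3-yl on a saturated chain carbon bound to an aromatic carbon. Within the data shown here, no measured step describes the effect of exchanging an aryl arm for a larger bicyclic one on this core; the two arm changes that were measured gave no readable size. Three compounds sitting at the limit give no hint that any arm so far brings the potency into the measurable range.

The expectation for compound 4 is therefore that the result in this assay again reaches the limit, with only a modest chance of a readable number. The expected value for compound 4 is 50000 nM, within 10000 nM to 100000 nM. The step this estimate implies, a number no higher from compound 3 to compound 4 (the limit leaves the size open), is expected to be small and not readable beyond the scatter.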

Compound 4, half-maximal effective concentration: > 50000 nM
Compound 4 was reported as a limit (the forecaster's own chance of this, stated with the estimate: 75%); the middle value sits exactly at the limit.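

The size of the steps linking compound 4 to compound 1, compound 2 and compound 3 cannot be read, because every result here is a limit and not a number: the limit of > 50000 nM in this assay, at which 4 of the 4 values shown sit.

The compounds shown leave open whether any arm on the shared core reaches a measurable value in this assay, and how far these four arms truly differ.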